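Shifting a chlorine on a 2,4,6-trisubstituted pyridine core? No — shifting chlorine

The source may hold more compounds than are shown below. What is called first, only, known or untested is meant among the compounds shown, and "the series" means these compounds.

Swapping where the chlorine sits

The compounds share one core, seen in compound 1 `Oc1cccc(-c2cc(-c3ccncc3)nc(-c3ccccc3Cl)c2)c1`, compound 2 `Oc1cccc(-c2cc(-c3ccco3)nc(-c3ccccc3Cl)c2)c1` and compound 3 `Oc1cccc(-c2cc(-c3ccc(Cl)cc3)nc(-c3ccsc3)c2)c1`. Going by the values given here, in a functional assay on DU-145 cells (Homo sapiens) for cytotoxicity, read by CCK-8 assay and cell counting, with a stated time of 2 days (a lower number here means a stronger inhibitor, a higher number a weaker inhibitor), compound 2 gives 1630 nM, while compound 3 gives 11600 nM, the higher of the two numbers known, the gap to compound 2 lying beyond the usual scatter. In this assay compound 1 gives "not determined" (no result reported). Compound 4 `Oc1cccc(-c2cc(-c3ccsc3)nc(-c3ccccc3Cl)c2)c1` differs from compound 3 by 2-chlorophenyl in place of 4-chlorophenyl on an aromatic carbon. Among the compounds with values here, no measured pair shows this change directly. Because compound 2, which also carries a 2-chlorophenyl group, gives 1630 nM, compound 4 is expected to move toward a lower number than compound 3, the expected step being a 3.9-fold lower number from compound 3 to compound 4 (0.59 log units; beyond the scatter). For compound 4 the estimate is 3000 nM, within a range of 900 nM to 10000 nM.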

Compound 4, half-maximal inhibitory concentration: 1970 nM
Compound 4: middle estimate off by 1.5-fold (0.18 log units), on the high side, and the stated range covers the measured number.
By their numbers in this assay, from the lowest: compounds 2 and 4 (each within the scatter of the next); then compound 3.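

In this assay, moving the chlorine alone gives a 5.9-fold lower number from compound 3 to compound 4 (0.77 log units; beyond the scatter) and so shows that its place on this phenyl ring matters by itself. The earlier compounds shown here could not show this, since compound 2 and compound 3 differ in two places. With the 2-chlorophenyl group held fixed, thiophen-3-yl in place of furan-2-yl gives a 1.2-fold higher number from compound 2 to compound 4 (0.08 log units; within the scatter) and leaves the number within the scatter. No measurement here explains either result. On these data alone, whether an amine or a carboxylic acid in place of the chlorine would keep this level remains open.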